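A few compounds are considered here, and "the series" means these few. Any claim that something is new, unique, unknown or untested is made for them only; others in the source may bear on it.

Three compounds have been measured in a functional assay for inhibition of sodium/hydrogen exchanger (Oryctolagus cuniculus); on this read-out lower numbers stand for stronger inhibition and higher numbers for weaker inhibition:

Compound 1, `CCN(CC)Cc1cc(Br)c(S(C)(=O)=O)cc1C(=O)N=C(N)N`, gives 9500 nM.
Compound 2, `CCCCCc1cc(C)c(C(=O)N=C(N)N)cc1S(C)(=O)=O`, gives 27 nM.
Compound 3, `Cc1c(C(=O)N=C(N)N)cc(S(C)(=O)=O)c(C)c1C`, gives 55 nM.

Compound 2 gives the lowest number of the three. Its nearest neighbour is compound 3, whose number is higher by a gap that goes beyond the usual scatter of repeated measurements; compound 1 sits far higher still, well beyond the scatter. Going by the values given here, no pair of these three compounds differs in only one place, so no single structural step has been isolated so far.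

The next compound, compound 4, `Cc1cc(Sc2ccccc2Cl)c(S(C)(=O)=O)cc1C(=O)N=C(N)N`, has not yet been measured. It differs from compound 2 by one change: (2-chlorophenyl)sulfanyl in place of pentyl on an aromatic carbon. Among the compounds with values here, nothing among the measured compounds shows how this exchange shifts the number: compound 1 and compound 3 carry other groups at several positions, so their values say only that each gives a higher number than compound 2 in this assay.

For compound 4 the expected step of a 2.2-fold higher number from compound 2 to compound 4 (0.35 log units; beyond the scatter) is a small rise in the number, one that may well stay within the scatter. Compound 4 is therefore expected to give about 60 nM, with a range from 15 nM to 250 nM.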

Compound 4, half-maximal inhibitory concentration: 14 nM
Compound 4: the middle estimate sits 4.3-fold (0.63 log units) above what was measured; measured number below the stated range.
By their numbers in this assay, from the lowest: compounds 4 and 2 (each within the scatter of the next); then compound 3; then compound 1.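

In this assay, putting (2-chlorophenyl)sulfanyl in place of pentyl gives a 1.9-fold lower number from compound 2 to compound 4 (0.29 log units; within the scatter) and so leaves the two compounds indistinguishable on this read-out. This position, on an aromatic carbon ortho to a methylsulfonyl group, therefore carries either an open pentyl chain or a group with a six-membered aromatic ring and a chlorine, with no change in inhibition beyond the scatter. Nothing measured here explains why such different groups give matching numbers.

On these data alone, how a phenoxy group or a plain phenylsulfanyl group at this position would compare remains open, so the separate roles of the sulfur and the chlorine are unsettled. As far as these compounds go, whether a carboxylic acid or an amine there would give a similar number is equally open.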